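Cyclopropyl for methyl on the pyrazole of compound 2

This account rests on a few compounds, and the source may have more. Where it says the series, first, only, none or still open, it means among the compounds named here.

Measured compounds:
- compound 1, `Fc1ccc(CNc2nc(Nc3cc(C4CC4)[nH]n3)c3ccccc3n2)c(F)c1`, 4.7 nM
- compound 2, `Cc1cc(Nc2nc(NCc3ccc(F)cc3F)nc3cc(Cl)ccc23)n[nH]1`, 15 nM

In an assay for inhibition of high affinity nerve growth factor receptor (Homo sapiens), read by HTRF, with a stated time of 30 min, in the presence of a further agent that is not named here (a lower number here means a stronger inhibitor, a higher number a weaker inhibitor), compound 2 gives 15 nM, the higher of the two numbers shown, while compound 1 gives 4.7 nM, a difference that lies beyond the usual scatter. Compound 3, `Fc1ccc(CNc2nc(Nc3cc(C4CC4)[nH]n3)c3ccc(Cl)cc3n2)c(F)c1`, keeps the whole of compound 2 except for one change: cyclopropyl in place of methyl on an aromatic carbon. For the measured compounds named here, compound 1 also carries the cyclopropyl on that ring, yet it differs from compound 2 in a second place as well, so no step for the cyclopropyl alone can be read from the measured pair. The expectation is therefore a modest move toward a lower number, a 2.1-fold lower number from compound 2 to compound 3 (0.33 log units; beyond the scatter), with the possibility of no change beyond the scatter. For compound 3 the estimate is 7 nM, within a range from 2.5 nM to 25 nM.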

Compound 3, half-maximal inhibitory concentration: 290 nM
For compound 3 the middle estimate is 41-fold (1.62 log units) below the measured one; measured number outside the range, above it.
By their numbers in this assay, from the lowest: compound 1; then compound 2; then compound 3.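

In this assay, cyclopropyl in place of methyl on the pyrazole gives a 19-fold higher number from compound 2 to compound 3 (1.29 log units; beyond the scatter), so with the chloro present, this carbon of the ring does not accept the larger group as it does methyl. Adding the chloro to the cyclopropyl compound gives a 62-fold higher number from compound 1 to compound 3 (1.79 log units; beyond the scatter), so both single changes that lead to compound 3 raise the number by a wide margin, and neither group is harmless in the presence of the other. Nothing available explains why the number rises in either step.

The compounds shown leave open whether the step from methyl to cyclopropyl would be as large on the core without the chloro. Also open, on these data alone, is how an ethyl or an isopropyl on this pyrazole carbon, or a fluoro in place of the chloro, would compare.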